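This account rests on a few compounds, and the source may have more. Where it says the series, first, only, none or still open, it means among the compounds named here.

Three compounds with one shared core, differing only in the group on an ether oxygen, were tested in a functional assay on A549 cells (Homo sapiens) for antiproliferative activity, read by MTT assay, with a stated time of 48 h; on this read-out higher numbers stand for weaker inhibition and lower numbers for stronger inhibition. Compound 1 `COc1cc(-c2nnc3c(OC4COC4)cc(-c4ccc5[nH]ccc5c4)cn23)cc(OC)c1OC`, carrying oxetan-3-yl, gives 9810 nM. Compound 2 `COc1cc(-c2nnc3c(OCC(F)(F)F)cc(-c4ccc5[nH]ccc5c4)cn23)cc(OC)c1OC`, carrying 2,2,2-trifluoroethyl, gives 585 nM, the lower of the two actual numbers. Compound 3 `COc1cc(-c2nnc3c(OC4CN(C(C)(C)C)C4)cc(-c4ccc5[nH]ccc5c4)cn23)cc(OC)c1OC`, carrying 1-(tert-butyl)azetidin-3-yl, reads > 10000 nM, which is a limit of the assay and not a number. Exchanging that one group can therefore matter a great deal: the read-out shifts by a 17-fold lower number from compound 1 to compound 2 (1.22 log units; beyond the scatter) and by an at least 17-fold higher number from compound 2 to compound 3 (1.23 log units; beyond the scatter), both large steps.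

Compound 4 `COc1cc(-c2nnc3c(OCC(F)(F)F)cc(-c4ccc5c(ccn5C)c4)cn23)cc(OC)c1OC` keeps the 2,2,2-trifluoroethyl group and changes a different place, with methyl in place of hydrogen on an aromatic nitrogen, turning 1H-indol-5-yl into 1-methyl-1H-indol-5-yl (methyl in place of hydrogen on an aromatic nitrogen). For the measured compounds named here, none of the measured steps touches this nitrogen, so they show how much the ether group matters but give no direct size for this change. The starting point is thus compound 2 at 585 nM, and no shift beyond the scatter is expected, though the uncertainty is wide. The expected step is a 1.2-fold higher number from compound 2 to compound 4 (0.08 log units; within the scatter). For compound 4 the estimated value is 700 nM, within an expected range of 200 nM to 2500 nM.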

Compound 4, half-maximal inhibitory concentration: 614 nM
For compound 4 the middle estimate is 1.1-fold (0.06 log units) above the measured one, and the stated range covers the measured number.
By their numbers in this assay, from the lowest: compounds 2 and 4 (each within the scatter of the next); then compound 1. At a limit, above all of these: compound 3.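

In this assay, for the compounds shown here, the new result gives the first direct reading at this aromatic nitrogen, which carries a hydrogen in all three earlier compounds: methyl in place of that hydrogen gives a 1.0-fold higher number from compound 2 to compound 4 (0.02 log units; within the scatter), so the two compounds read alike. With 2,2,2-trifluoroethyl on the ether oxygen, the hydrogen on this nitrogen is therefore not needed to keep the antiproliferative reading, and one added carbon here does not produce a step like the one seen on exchanging the ether group, a 17-fold lower number from compound 1 to compound 2 (1.22 log units; beyond the scatter). Nothing measured here accounts for why this change leaves the reading where it is.

The compounds shown leave open whether methyl on this nitrogen would read the same alongside oxetan-3-yl or 1-(tert-butyl)azetidin-3-yl on the ether oxygen, since the only pair that isolates this change carries 2,2,2-trifluoroethyl. They also leave open how much room this nitrogen offers beyond a single methyl, for instance with an ethyl group, a longer chain, an acetyl group or a chain ending in an amine.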